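The compounds below may be only part of what the source reports. "The series", "measured", "known", "first", "only" and "open" are said of these compounds alone.

Working notes on the sulfonyl series. Three compounds have been run so far: compound 1 `O=C(NCc1ccc(S(=O)(=O)c2cc(F)cc(F)c2)cc1)N1Cc2ccncc2C1`, compound 2 `CC(C)n1cc(S(=O)(=O)c2ccc(CNC(=O)N3Cc4ccncc4C3)cc2)cn1` and compound 3 `O=C(NCc1ccc(S(=O)(=O)N2CCC(O)CC2)cc1)N1Cc2ccncc2C1`, all sharing the same core and differing only in the group on the sulfonyl sulfur. In an ADME assay on microsomes from liver (Homo sapiens) for pharmacokinetics, read by LC-MS, with a stated time of 60 min, tested at 1 uM (a lower number here means slower removal, a higher number faster removal of the compound), compound 1 gives 8 mL/min/kg. In this assay compound 2 gives 4 mL/min/kg, and compound 3 gives 6 mL/min/kg. The number for compound 2 is the lowest of the three as written, but the steps joining it to the others, a 2.0-fold lower number from compound 1 to compound 2 (0.30 log units; within the scatter) and a 1.5-fold higher number from compound 2 to compound 3 (0.18 log units; within the scatter), both sit within the scatter, as does a 1.3-fold lower number from compound 1 to compound 3 (0.12 log units; within the scatter); no ordering can be read from them.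

Compound 4 `O=C(NCc1ccc(S(=O)(=O)N2CC3(CCOCC3)C2)cc1)N1Cc2ccncc2C1` has not yet been measured. Relative to compound 2 the change is a group of 9 heavy atoms (7 carbon, 1 nitrogen, 1 oxygen; one four-membered non-aromatic ring with 1 hetero atom, one six-membered non-aromatic ring with 1 hetero atom) in place of a group of 8 heavy atoms (6 carbon, 2 nitrogen; one five-membered aromatic ring with 2 hetero atoms), on a sulfonyl sulfur. The step most like it, a non-aromatic ring entering in place of the pyrazolyl group, is a 1.5-fold higher number from compound 2 to compound 3 (0.18 log units; within the scatter), and the swap of the difluorophenyl for a non-aromatic ring gave a 1.3-fold lower number from compound 1 to compound 3 (0.12 log units; within the scatter). Every change at this position has so far stayed within the scatter, so no step beyond it is expected here. The expected step for compound 4 is a 1.5-fold higher number from compound 2 to compound 4 (0.18 log units; within the scatter). Compound 4 is estimated at 6 mL/min/kg, within 3 mL/min/kg to 12 mL/min/kg.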

Compound 4, clearance: 13 mL/min/kg
Compound 4: the middle estimate sits 2.2-fold (0.34 log units) below what was measured; the measured number lies above the stated range.
By their numbers in this assay, from the lowest: compounds 2, 3, 1 and 4 (each within the scatter of the next, the first and the last beyond it).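

In this assay, for the compounds shown here, the group on the sulfonyl sulfur can now be seen to matter: the steps of a 3.3-fold higher number from compound 2 to compound 4 (0.51 log units; beyond the scatter) and a 2.2-fold higher number from compound 3 to compound 4 (0.34 log units; beyond the scatter) are the first at this position to lie beyond the scatter. A non-aromatic ring alone does not account for this, as compound 3 also carries one, while the step of a 1.6-fold higher number from compound 1 to compound 4 (0.21 log units; within the scatter) stays within the scatter, so the entering group stands apart from compounds 2 and 3 but not from compound 1. No measurement shown gives a reason for these steps.

Whether the four-membered ring or the six-membered ring carries the step stays open, as the two enter together in compound 4 and nothing shown separates them. As far as these compounds go, how an open-chain amine on the sulfonyl sulfur would stand in this assay is also open.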